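The source may report more compounds than this note shows. Statements on the series, on what has been measured and on what is new or still open speak of the compounds shown alone.

Of the compounds shown here, three built on one shared core have been tested in a functional assay on MCF7 cells (Homo sapiens) for antiproliferative activity, read by MTT assay, with a stated time of 48 h; a lower number here means a stronger inhibitor, a higher number a weaker inhibitor. Compound 1 `COc1cc(/C=C/C(C)=O)ccc1OCc1cn(-c2ccc(/N=N/c3ccccc3)cc2)nn1` gives 75900 nM. Compound 2 `COc1cc(/C=C/C(C)=O)ccc1OCc1cn(-c2ccc([N+](=O)[O-])cc2)nn1` reaches only a limit of the assay, > 100000 nM. Compound 3 `COc1cc(/C=C/C(C)=O)ccc1OCc1cn(-c2ccc(C)cc2)nn1` likewise reaches only a limit, > 100000 nM. Compound 3 therefore stands at the limit of > 100000 nM in this assay, at which 2 of the 3 values shown sit, with no number of its own. The steps of an at least 1.3-fold higher number from compound 1 to compound 2 (0.11 log units; that floor lies within the scatter) and an at least 1.3-fold higher number from compound 1 to compound 3 (0.11 log units; that floor lies within the scatter) are at-least steps whose floors lie within the usual scatter, and the step that the two limits leave unreadable from compound 2 to compound 3 cannot be read, since both ends are limits. Compound 4 `CCOC(=O)c1ccc(-n2cc(COc3ccc(/C=C/C(C)=O)cc3OC)nn2)cc1` differs from compound 3 by ethoxycarbonyl in place of methyl on an aromatic carbon. Every measured step alters the same group that this change alters, and none of them yields a readable size, while two of the three values sit at the limit. For compound 4 the expected step is a number no higher from compound 3 to compound 4 (the limit leaves the size open), meaning none beyond the scatter. Compound 4 is accordingly expected to give about 100000 nM, within 30000 nM to 300000 nM, most probably as a limit once more.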

Compound 4, half-maximal inhibitory concentration: > 100000 nM
Compound 4: only a limit was reported (the forecaster's own chance of this, stated with the estimate: 70%); the middle value sits exactly at the limit.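

Ethoxycarbonyl, on an aromatic carbon para to a large group, brings two hydrogen-bond acceptors where methyl has none, yet compound 4 still has no number of its own, and it joins the others at one limit: the limit of > 100000 nM in this assay, at which 3 of the 4 values shown sit.

The only step with a floor is an at least 1.3-fold higher number from compound 1 to compound 4 (0.11 log units; that floor lies within the scatter), so no difference beyond the usual scatter is shown at this place. The steps among compound 2, compound 3 and compound 4 cannot be read, since both ends of each are limits.

The compounds shown leave open whether another group at this place, such as an amine or a carboxylic acid, would give a measured number. They also leave open whether compound 2, compound 3 and compound 4 differ from one another at all.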